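A few compounds are considered here, and "the series" means these few. Any claim that something is new, unique, unknown or untested is made for them only; others in the source may bear on it.

Compound 1 `O=S(=O)(NCCCNCc1cccc2ccccc12)c1cc(C(F)(F)F)cc(C(F)(F)F)c1` gives 2800 nM in a functional assay on MIA PaCa-2 cells (Homo sapiens) for inhibition, read by MTT assay, with a stated time of 72 h; a lower number here means a stronger inhibitor of growth, a higher number a weaker inhibitor of growth.
Compound 2 `CC(C)(C)c1ccc(CNCCNS(=O)(=O)c2cc(C(F)(F)F)cc(C(F)(F)F)c2)cc1` gives 15000 nM in this assay.
Compound 3 `CCCCc1ccc(S(=O)(=O)NCCCCCCNCc2ccc(Br)cc2)cc1` gives 5700 nM in this assay.

Compound 1 stands lowest of the three numbers; compound 3 lies nearest, and compound 2 sits furthest away, both beyond the usual scatter. Compound 4 `COc1ccc(CNCCCNS(=O)(=O)c2cc(C(F)(F)F)cc(C(F)(F)F)c2)cc1OC` has not yet been measured in this assay. It differs from compound 1 in one place: 3,4-dimethoxyphenyl in place of naphthalen-1-yl on a saturated chain carbon bound to an amine nitrogen. Within the data shown here, no measured pair in this set shows this change, so its size is unknown from the data. Compound 4 is expected to come out somewhat weaker than compound 1, a step of a 2.1-fold higher number from compound 1 to compound 4 (0.33 log units; beyond the scatter) that may reach beyond the scatter. Compound 4 is estimated at 6000 nM, within a range from 2500 nM to 15000 nM.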

Compound 4, concentration for 50% growth inhibition: 2800 nM
The estimate for compound 4 lay 2.1-fold (0.33 log units) above the measured number; measured number inside the range.
By their numbers in this assay, from the lowest: compounds 1 and 4 (each within the scatter of the next); then compound 3; then compound 2.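

In this assay, 3,4-dimethoxyphenyl in place of naphthalen-1-yl on a saturated chain carbon bound to an amine nitrogen gives no change at the digits printed from compound 1 to compound 4 (within the scatter). At this position, then, one aromatic ring of carbon bearing two hydrogen-bond acceptors serves as well as two such rings without acceptors, at an equal heavy-atom count. Nothing at hand explains this equivalence. From the compounds shown here alone, it remains open whether a plain phenyl, a pyridine ring or a single methoxy group at this place would give a similar number.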